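Adding a second chlorine to a purine cytotoxin

A few compounds are considered here, and "the series" means these few. Any claim that something is new, unique, unknown or untested is made for them only; others in the source may bear on it.

Two compounds sharing a purine-like core carrying a benzyl arm have been tested in a functional assay on SW-620 cells (Homo sapiens) for cytotoxicity, read by sulforhodamine B assay, with a stated time of 48 h; on this read-out lower numbers stand for higher toxicity in this test and higher numbers for lower toxicity in this test. Compound 1 `ClCc1cccc(Cn2cnc3ncnc(Cl)c32)c1` gives 7410 nM in this assay, the lowest of the two numbers seen, and therefore the most toxic of the pair, since its gap to compound 2 `ClCc1ccc(Cn2cnc3nc(Cl)nc(Cl)c32)cc1`, which gives 64600 nM, lies beyond the scatter. Compound 2 differs from compound 1 in two places at once, so the two values cannot be traced to a single change.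

Compound 3 `ClCc1cccc(Cn2cnc3nc(Cl)nc(Cl)c32)c1` has not yet been measured. It differs from compound 1 by a single change: chloro in place of hydrogen on an aromatic carbon. For the measured compounds named here, no measured pair shows this change alone, so the expectation rests on the weaker showing of compound 2, which also carries the second chlorine. For compound 3 a step of a 2.0-fold higher number from compound 1 to compound 3 (0.31 log units; beyond the scatter) toward lower toxicity is expected, giving an estimated 15000 nM with a range from 5000 nM to 50000 nM.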

Compound 3, concentration lethal to 50% of the cells: 4070 nM
Beside the measured number, compound 3's estimate is 3.7-fold (0.57 log units) above it; the whole stated range lies above it.
By their numbers in this assay, from the lowest: compounds 3 and 1 (each within the scatter of the next); then compound 2.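

In this assay, putting chloro in place of hydrogen on the aromatic carbon between two ring nitrogen atoms gives a 1.8-fold lower number from compound 1 to compound 3 (0.26 log units; within the scatter), so this position accepts a chloro group without a change that can be told from the scatter. Compound 2 also carries this chloro group and gives 64600 nM, while compound 3 gives 4070 nM, so the chloro group alone does not go with the high number of compound 2.

Going by these compounds, whether a different group at this position, such as an amine or a methoxy group, would also leave the number within the scatter remains open. Nothing measured here explains why this chloro group makes so little difference.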